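Fluoro for hydrogen in a pyrazole-free series: compound 4

The source may hold more compounds than are shown below. What is called first, only, known or untested is meant among the compounds shown, and "the series" means these compounds.

Measured compounds in a functional assay on OVCAR cells (Homo sapiens) for inhibition, read by MTT assay, with a stated time of 48 h; on this read-out higher numbers stand for weaker inhibition of growth and lower numbers for stronger inhibition of growth:
compound 1 `O=[N+]([O-])c1ccc(-c2cc(-c3ccccc3)n[nH]2)cc1` gives 7200 nM
compound 2 `COc1ccc(-c2cc(-c3ccc([N+](=O)[O-])cc3)[nH]n2)cc1` gives 27300 nM
compound 3 `COc1ccc(-c2cc(-c3ccccc3)n[nH]2)cc1` gives 9900 nM

Compound 3 stands second highest of the three numbers in this assay. Compound 1 is nearest, the step of a 1.4-fold higher number from compound 1 to compound 3 (0.14 log units; within the scatter) lying within the scatter, so no order between compound 1 and compound 3 can be read. Compound 2 is furthest: its number is higher than that of compound 3 and the gap lies beyond the scatter.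

Compound 4 `COc1ccc(-c2cc(-c3ccc(F)cc3)n[nH]2)cc1` differs from compound 3 by fluoro in place of hydrogen on an aromatic carbon. Among the compounds with values here, no measured step involves fluoro. The two steps at hand, a 3.8-fold higher number from compound 1 to compound 2 (0.58 log units; beyond the scatter) for methoxy in place of hydrogen and a 1.4-fold higher number from compound 1 to compound 3 (0.14 log units; within the scatter) for methoxy in place of nitro, show that changes at this kind of position have ranged from modest to within the scatter. With nothing that bears directly on fluoro, the expected step of a 1.0-fold higher number from compound 3 to compound 4 (0.00 log units; within the scatter) is none beyond the scatter in this assay. Compound 4 is therefore estimated at 10000 nM, expected between 4000 nM and 25000 nM.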

Compound 4, concentration for 50% growth inhibition: 14000 nM
Compound 4: middle estimate off by 1.4-fold (0.15 log units), on the low side; measured number inside the range.
By their numbers in this assay, from the lowest: compounds 1, 3, 4 and 2 (each within the scatter of the next, the first and the last beyond it).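

In this assay, fluoro in place of hydrogen on an aromatic carbon, para to a large group, gives a 1.4-fold higher number from compound 3 to compound 4 (0.15 log units; within the scatter), so this change cannot be told from no change at all. The position now carries three groups on the methoxy series: compound 3 with hydrogen gives 9900 nM, compound 4 with fluoro sits within the scatter of it, and compound 2 with nitro gives 27300 nM, which is also within the scatter of compound 4, so fluoro cannot be separated from either neighbour. No measurement on hand explains the small difference.

As far as these compounds go, whether an amine or a carboxylic acid at this position would move the number clearly beyond the scatter stays open. Also open, from the compounds shown here alone, is whether the fluoro step holds in a compound without the methoxy group.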